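A few compounds are considered here, and "the series" means these few. Any claim that something is new, unique, unknown or untested is made for them only; others in the source may bear on it.

Three anilino compounds on the shared core have been measured in an assay on cells for inhibition of S-adenosylmethionine decarboxylase proenzyme (Homo sapiens), read by mass spectrometry, at pH 7.2; a lower number here means a stronger inhibitor, a higher number a weaker inhibitor. Compound 1 `Cc1cc(Nc2cccc(S(F)(F)(F)(F)F)c2)nc(N)n1` gives > 180000 nM, which is a limit of the assay rather than a number. Compound 2 `Cc1cc(Nc2cccc(Cl)c2)nc(N)n1` gives > 180000 nM, also a limit. Compound 3 `Cc1cc(Nc2cccc(F)c2)nc(N)n1` gives > 180000 nM, again a limit. The steps a step that the two limits leave unreadable from compound 1 to compound 2, a step that the two limits leave unreadable from compound 1 to compound 3 and a step that the two limits leave unreadable from compound 2 to compound 3 cannot be read, because of the limit of > 180000 nM in this assay, at which 3 of the 3 values shown sit. Compound 4 `Cc1cc(Nc2cc(F)cc(F)c2)nc(N)n1` differs from compound 3 by fluoro in place of hydrogen on an aromatic carbon. Within the data shown here, no measured step bears readably on this change, as every value so far sits at the limit. For compound 4 the step that the limit leaves unreadable from compound 3 to compound 4 is expected to leave the series at the limit as well. Compound 4 is therefore estimated at 250000 nM, in the range 100000 nM to 600000 nM.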

Compound 4, half-maximal inhibitory concentration: > 180000 nM
Compound 4: no number, only a limit; the forecaster's own chance of this, stated with the estimate: 85%; the middle value lies beyond the limit too.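

No new step can be read between compound 3 and compound 4, as both values are limits and not numbers: the limit of > 180000 nM in this assay, at which 4 of the 4 values shown sit. The compounds shown leave open which change on the shared core, if any, would give a measurable value.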